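Notes on the 4-nitrophenyl to 4-methylphenyl step

A few compounds are considered here, and "the series" means these few. Any claim that something is new, unique, unknown or untested is made for them only; others in the source may bear on it.

In a functional assay on MDA-MB-231 cells (Homo sapiens) for antiproliferative activity, read by trypan blue exclusion, with a stated time of 24 h (on this read-out lower numbers stand for stronger inhibition and higher numbers for weaker inhibition), compound 1 `O=C1NC(=O)/C(=C/c2cn(Cc3ccc([N+](=O)[O-])cc3)c3ccccc23)N1` gives 23300 nM. Compound 2 `Cc1ccc2c(c1)c(/C=C1\NC(=O)NC1=O)cn2Cc1ccccc1` gives 20100 nM and compound 3 `O=C1NC(=O)/C(=C/c2cn(Cc3ccccc3)c3ccc(Br)cc23)N1` gives 12400 nM. All three values lie within the scatter of one another, so compound 1 has no distinct standing among them. Compound 4 `Cc1ccc(Cn2cc(/C=C3\NC(=O)NC3=O)c3ccccc32)cc1` carries methyl in place of nitro on an aromatic carbon, para to a large group: methyl in place of nitro on an aromatic carbon. Within the data shown here, no measured step covers this exact change. Among the measured compounds shown here, the only measured step, a 1.6-fold lower number from compound 2 to compound 3 (0.21 log units; within the scatter), also swaps a group on an aromatic carbon, at a different place, and it stays within the scatter. No step beyond the scatter is therefore expected in this assay. The expected step is a 1.2-fold lower number from compound 1 to compound 4 (0.07 log units; within the scatter). Compound 4 is estimated at 20000 nM, with an expected range of 11000 nM to 36000 nM.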

Compound 4, half-maximal inhibitory concentration: 22100 nM
Beside the measured number, compound 4's estimate is 1.1-fold (0.04 log units) below it; the measured number falls inside the stated range.
By their numbers in this assay, from the lowest: compounds 3, 2, 4 and 1 (each within the scatter of the next).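

The 4-nitrophenyl to 4-methylphenyl change gives, in this assay, a 1.1-fold lower number from compound 1 to compound 4 (0.02 log units; within the scatter), so nitro and methyl are not told apart at this place, para to a large group. Among these compounds, this is the first pair that differs at this position, and it adds a second one-place change that stays within the scatter. No supporting measurement bears on this result.

From the compounds shown here alone, whether an amine, a carboxylic acid or a longer chain at this position would give a step beyond the scatter stays open. Also open, going by these compounds, is whether any change on the shared core would do so.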